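A Methyl Step in a Cell Toxicity Series

The source may report more compounds than this note shows. Statements on the series, on what has been measured and on what is new or still open speak of the compounds shown alone.

- Compound 1 `CC(NC(=O)c1ncc([N+](=O)[O-])n1C)c1ccc(F)cc1`: > 100000 nM
- Compound 2 `O=C(NCc1ccc(F)cc1)c1ncc([N+](=O)[O-])[nH]1`: > 100000 nM

Both compounds were tested in a toxicity assay on HEK293 cells (Homo sapiens) for inhibition, read by resazurin assay, with a stated time of 24 h; a lower number here means that less compound is tolerated, a higher number that more compound is tolerated. Compound 1 gives > 100000 nM, which is a limit of the assay and not a number. Compound 2 gives > 100000 nM, which is likewise a limit. Compound 3 `CC(NC(=O)c1ncc([N+](=O)[O-])[nH]1)c1ccc(F)cc1` has not yet been measured, and it differs from compound 2 by methyl in place of hydrogen on a saturated chain carbon bound to an amide-type nitrogen and an aromatic carbon. Compound 3 is expected to differ from compound 2 by no step beyond the scatter in this assay, due to the limit of > 100000 nM in this assay, at which 2 of the 2 values shown sit. The expected change, a number no higher from compound 2 to compound 3 (the limit leaves the size open), is therefore small. Compound 3 is estimated at 100000 nM, with an expected range of 50000 nM to 200000 nM.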

Compound 3, half-maximal cytotoxic concentration: > 100000 nM
Compound 3: a limit, no number (the forecaster's own chance of this, stated with the estimate: 90%); the middle value sits exactly at the limit.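

In this assay compound 3 gives > 100000 nM, a limit of the assay and not a number. Among these compounds, no step from compound 1 or compound 2 to compound 3 can be read. The compounds shown leave open whether either methyl changes how much compound is tolerated.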